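The source may report more compounds than this note shows. Statements on the series, on what has been measured and on what is new or still open speak of the compounds shown alone.

Compound 1 `COc1ccc(C(=O)/C=C/c2cc3ccccc3[nH]c2=O)cc1` and compound 2 `O=C(/C=C/c1cc2ccccc2[nH]c1=O)c1ccc(O)cc1` share the same core and differ only at the oxygen on the distal aromatic ring. In a functional assay on ACHN cells (Homo sapiens) for cytotoxicity, read by sulforhodamine B assay, with a stated time of 24 h (on this read-out lower numbers stand for stronger inhibition of growth and higher numbers for weaker inhibition of growth), compound 1 gives 16700 nM and compound 2 gives 8860 nM; the step of a 1.9-fold lower number from compound 1 to compound 2 (0.28 log units; within the scatter) stays inside the scatter. Compound 2 thus sits at the smaller of the two numbers, with compound 1 nearest, but the gap between them is too small to rank the pair. Compound 3 `O=C(/C=C/c1cc2ccccc2[nH]c1=O)c1ccc(Cl)cc1` is the next member. Its change from compound 2 is chloro in place of hydroxy on an aromatic carbon; the same difference cut one bond further out reads 4-hydroxyphenyl to 4-chlorophenyl. Among the measured compounds shown here, no measured step replaces hydroxy with chloro. For the measured compounds named here, the only step in hand, a 1.9-fold lower number from compound 1 to compound 2 (0.28 log units; within the scatter), concerns methyl against hydrogen on that oxygen and shows nothing beyond the scatter, so it bears on this change only loosely. On that basis no movement beyond the scatter is expected from compound 2 to compound 3. The expected step is a 1.0-fold higher number from compound 2 to compound 3 (0.01 log units; within the scatter). Compound 3 is estimated at 9000 nM, with a range from 3000 nM to 30000 nM.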

Compound 3, concentration for total growth inhibition: 27400 nM
Compound 3: middle estimate off by 3.0-fold (0.48 log units), on the low side, within the range that was stated.
By their numbers in this assay, from the lowest: compounds 2, 1 and 3 (each within the scatter of the next, the first and the last beyond it).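

In this assay, among the compounds shown here, this aromatic carbon does respond to the group it carries: a 3.1-fold higher number from compound 2 to compound 3 (0.49 log units; beyond the scatter) is the only step so far that clears the scatter, though it remains modest, and it shows that chloro and hydroxy are not interchangeable here. The comparison with the methyl ether is less clear, since a 1.6-fold higher number from compound 1 to compound 3 (0.22 log units; within the scatter) leaves chloro and methoxy unresolved, while compound 1 also cannot be separated from compound 2, so the three compounds do not split cleanly into a hydroxy group and a non-hydroxy group; only the ends of the series, compound 2 and compound 3, stand apart. No available data account for the difference between hydroxy and chloro at this carbon.

From the compounds shown here alone, whether an amine, a carboxylic acid or a longer chain such as butoxy on this carbon would track with compound 2 or with compound 3 remains open. Also open, going by these compounds, is whether the gap between hydroxy and chloro persists with the same groups elsewhere on the ring or on a different core.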